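Morpholine versus thiomorpholine in a thiosemicarbazide series

The compounds below may be only part of what the source reports. "The series", "measured", "known", "first", "only" and "open" are said of these compounds alone.

Of the compounds shown here, three have been measured in a functional assay on A-375 cells (Homo sapiens) for cytotoxicity, read by MTT assay, with a stated time of 72 h; a lower number here means a stronger inhibitor, a higher number a weaker inhibitor. Compound 1 `Cc1ccnc(/C(N)=N/NC(=S)N2CCOCC2)c1` gives 1600 nM and compound 2 `Cc1ccnc(/C(N)=N/NC(=S)N2CCSCC2)c1` gives 1200 nM. These two differ by morpholin-4-yl in place of thiomorpholin-4-yl on a thiocarbonyl carbon, and the step of a 1.3-fold higher number from compound 2 to compound 1 (0.12 log units; within the scatter) lies within the scatter. Compound 3 `N/C(=N\NC(=S)N1CCSCC1)c1ccc(F)cn1` gives 900 nM; its core differs from that of compound 2, but the difference between the two cores is not broken down here. Compound 4 `N/C(=N\NC(=S)N1CCOCC1)c1ccc(F)cn1` has not yet been measured. It differs from compound 3 by morpholin-4-yl in place of thiomorpholin-4-yl on a thiocarbonyl carbon, the same change at the same place as the one already seen. Because a 1.3-fold higher number from compound 2 to compound 1 (0.12 log units; within the scatter) stayed within the scatter, a step of similar size is expected here, namely a 1.3-fold higher number from compound 3 to compound 4 (0.12 log units; within the scatter). Compound 4 is therefore estimated at 1200 nM, with an expected range from 600 nM to 2400 nM.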

Compound 4, half-maximal inhibitory concentration: 1500 nM
Compound 4: the middle estimate sits 1.3-fold (0.10 log units) below what was measured, within the range that was stated.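

In this assay the new step reads a 1.7-fold higher number from compound 3 to compound 4 (0.22 log units; within the scatter). Morpholin-4-yl in place of thiomorpholin-4-yl on a thiocarbonyl carbon gives steps on the two cores that agree within the scatter: the same change on two cores in this assay, a 1.3-fold higher number (0.12 log units; within the scatter) from compound 2 to compound 1 and a 1.7-fold higher number (0.22 log units; within the scatter) from compound 3 to compound 4, 1.3-fold (0.10 log units) apart, within the scatter of two such steps. Each step on its own also lies within the scatter, so the pair shows neither a real effect of this change on either core nor a rule that extends beyond these two cores.

Open, from the compounds shown here alone, is whether piperidin-1-yl or piperazin-1-yl on the thiocarbonyl carbon would move the number beyond the scatter on either core. Also open is what the difference between the two cores contributes, as no pair shown isolates it.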